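Compound 4: tert-butyl for cyclopropylmethyl

This account rests on a few compounds, and the source may have more. Where it says the series, first, only, none or still open, it means among the compounds named here.

Measured in a functional assay on a cell-free system (plasma, Homo sapiens), with a stated time of 3 min; a lower number here means a stronger inhibitor, a higher number a weaker inhibitor:
- compound 1 `O=C(NCc1cc(Cl)ccc1-n1cnnn1)[C@@H]1C[C@@H]2C[C@@H]2N1C(=O)[C@H](O)CC1CC1`: 1700 nM
- compound 2 `CC(C)(C)[C@@H](O)C(=O)N1C[C@@H]2C[C@@H]2[C@H]1C(=O)NCc1cc(Cl)ccc1-n1cnnn1`: 570 nM
- compound 3 `O=C(NCc1cc(Cl)ccc1-n1cnnn1)[C@@H]1C[C@H]2C[C@H]2N1C(=O)[C@H](O)CC1CC1`: 850 nM

Not yet measured: compound 4 `CC(C)(C)[C@@H](O)C(=O)N1[C@H](C(=O)NCc2cc(Cl)ccc2-n2cnnn2)C[C@@H]2C[C@@H]21`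

Compound 1 stands at the upper end of these numbers, level within the scatter with compound 3 , while compound 2 reads a lower number than compound 1 by more than the scatter.

The change to compound 4 is tert-butyl in place of cyclopropylmethyl on a saturated chain carbon bound to a carbonyl carbon and an oxygen on a saturated carbon and leaves the core of compound 1 as drawn. Among the measured compounds shown here, no measured step makes this change. For the measured compounds named here, the only matched step is a 2.0-fold lower number from compound 1 to compound 3 (0.30 log units; within the scatter), and it comes with the fact that compounds 1 and 3 differ only in the configuration as drawn, so the group in question is untouched there and that step gives no direct size for this change. The nearest guide is compound 2 at 570 nM, which also carries tert-butyl, set against compound 1 at 1700 nM in this assay. That pair is not a matched step, so it supports only a tentative expectation of a lower number, and the range is kept wide.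

The expected change is a 2.3-fold lower number from compound 1 to compound 4 (0.36 log units; beyond the scatter) in this assay. The estimate for compound 4 is 750 nM, with an expected range from 280 nM to 2000 nM.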

Compound 4, half-maximal inhibitory concentration: 1500 nM
Estimate against measurement, compound 4: 2.0-fold (0.30 log units) below; measured number inside the range.
By their numbers in this assay, from the lowest: compounds 2, 3, 4 and 1 (each within the scatter of the next, the first and the last beyond it).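

In this assay, the change at the saturated chain carbon bound to a carbonyl carbon and an oxygen on a saturated carbon, with the core of compound 1 kept as drawn, gives a 1.1-fold lower number from compound 1 to compound 4 (0.05 log units; within the scatter), so tert-butyl and cyclopropylmethyl read level at this place. On this core, then, the three-membered ring of cyclopropylmethyl is not required to hold the number, since tert-butyl has no ring and the same count of 4 heavy atoms. Among the compounds shown here, this is the first matched reading of the group, as compound 2 at 570 nM also carries tert-butyl but stands in no matched step, and the one earlier matched step leaves the group untouched: the fact that compounds 1 and 3 differ only in the configuration as drawn.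

Open at this place is how a group of another kind reads on the same core, such as an amine, a carboxylic acid or a longer chain. Also open, on these data alone, is whether tert-butyl and cyclopropylmethyl stay level on the core as drawn in compound 3, and what part of the number of compound 2 belongs to its core rather than to its tert-butyl.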